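The source may report more compounds than this note shows. Statements on the series, on what has been measured and on what is new or still open speak of the compounds shown alone.

In a functional assay on PC-3 cells (Homo sapiens) for antiproliferative activity, read by MTT assay, with a stated time of 48 h; a lower number here means a stronger inhibitor, a higher number a weaker inhibitor:
- compound 1 `CCn1c(C(=O)NCC#N)ccc1C(CC)(CC)c1ccc(OCCC(O)(CC)CC)c(C)c1`: 17800 nM
- compound 2 `CCn1c(C(=O)NCCN)ccc1C(CC)(CC)c1ccc(OCCC(O)(CC)CC)c(C)c1`: 2420 nM
- compound 3 `CCn1c(C(=O)N(C)CC(=O)O)ccc1C(CC)(CC)c1ccc(OCCC(O)(CC)CC)c(C)c1`: 2250 nM
- compound 4 `CCn1c(C(=O)N(C)CCO)ccc1C(CC)(CC)c1ccc(OCCC(O)(CC)CC)c(C)c1`: not yet measured

Compound 3 stands at the low end of this small set. The gap to its nearest neighbour is a 1.1-fold lower number from compound 2 to compound 3 (0.03 log units; within the scatter), and the gap to the high end is a 7.9-fold lower number from compound 1 to compound 3 (0.90 log units; beyond the scatter).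

Compound 4 has hydroxymethyl in place of carboxy on a saturated chain carbon bound to an amide-type nitrogen.

For the measured compounds named here, no measured step makes this exact change. The closest one, a 1.1-fold lower number from compound 2 to compound 3 (0.03 log units; within the scatter), replaces the whole group on the carbonyl carbon without a change beyond the scatter. A larger step, a 7.4-fold lower number from compound 1 to compound 2 (0.87 log units; beyond the scatter), shows that changes in this region can count. In this assay, the expected step is therefore small: a 1.3-fold higher number from compound 3 to compound 4 (0.12 log units; within the scatter). For compound 4 the estimated value is 3000 nM, with an expected range of 1000 nM to 9000 nM.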

Compound 4, half-maximal inhibitory concentration: 3090 nM
The estimate for compound 4 lay 1.0-fold (0.01 log units) below the measured number; low and high end bracket the measured number.
By their numbers in this assay, from the lowest: compounds 3, 2 and 4 (each within the scatter of the next); then compound 1.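

In this assay replacing carboxy with hydroxymethyl on a saturated chain carbon bound to an amide-type nitrogen gives a 1.4-fold higher number from compound 3 to compound 4 (0.14 log units; within the scatter) and so stays within the scatter: this position holds its level without the carboxy group. Set against the (2-aminoethyl)amino group, the (2-hydroxyethyl)(methyl)amino group gives a 1.3-fold higher number from compound 2 to compound 4 (0.11 log units; within the scatter) and against the (cyanomethyl)amino group it gives a 5.8-fold lower number from compound 1 to compound 4 (0.76 log units; beyond the scatter) so only compound 1 stands apart. No supporting data explain these readings.

Still open, on these data alone, is whether a longer chain ending in hydroxyl, or a methoxy group in place of that hydroxyl, would read the same.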